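The compounds below may be only part of what the source reports. "The series", "measured", "known", "first", "only" and "open" are said of these compounds alone.

Measured in an ADME assay on MRC5 cells (Homo sapiens) for inhibition, with a stated time of 72 h; a higher number here means that more compound is needed for the effect, a lower number that less compound is needed:
compound 1 `CO[C@H]1CC[C@H](NC(=O)c2n[nH]cc2NC(=O)c2c(C)nc3ccccn23)CC1`: 34000 nM
compound 2 `CO[C@H]1CC[C@H](NC(=O)c2n[nH]cc2NC(=O)c2cnc3ccccn23)CC1`: 5900 nM
compound 3 `COc1cccc(OC)c1C(=O)Nc1c[nH]nc1C(=O)NCc1ncccc1C`: > 50000 nM (a limit of the assay)

Among the measured compounds shown here, compound 2 has the lower of the two numeric values in this assay, and the only measured step that reaches it is a 5.8-fold lower number from compound 1 to compound 2 (0.76 log units; beyond the scatter). Compound 3 reports only a limit, so it cannot be placed exactly against the other two.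

Next is compound 4 `CO[C@H]1CC[C@H](NC(=O)c2n[nH]cc2NC(=O)c2cc(F)cc(F)c2)CC1`, not yet measured. The change is a group of 8 heavy atoms (6 carbon, 2 fluorine; one six-membered aromatic ring of carbon only) in place of a group of 9 heavy atoms (7 carbon, 2 nitrogen; one five-membered aromatic ring with 2 hetero atoms, one six-membered aromatic ring with 1 hetero atom), on a carbonyl carbon; the 3,5-difluorophenyl group enters on a carbonyl carbon. For the measured compounds named here, no measured step covers this exchange. The nearest guide is a 5.8-fold lower number from compound 1 to compound 2 (0.76 log units; beyond the scatter), a change within the group that leaves here, and it is beyond the scatter. A step no larger than that one is therefore expected, and a move toward a higher number is more likely because compound 2 at 5900 nM already has the lowest numeric value. The expected change is a 2.0-fold higher number from compound 2 to compound 4 (0.31 log units; beyond the scatter), and this remains a weakly supported estimate. For compound 4 the estimated value is 12000 nM, with an expected range of 3500 nM to 40000 nM.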

Compound 4, half-maximal effective concentration: 600 nM
The estimate for compound 4 lay 20-fold (1.30 log units) above the measured number; measured number outside the range, below it.
By their numbers in this assay, from the lowest: compound 4; then compound 2; then compound 1. At a limit, above all of these: compound 3.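

In this assay, replacing the whole group on this carbonyl carbon, whose other neighbour is an amide-type nitrogen, gives a 9.8-fold lower number from compound 2 to compound 4 (0.99 log units; beyond the scatter), whereas the earlier step, a 5.8-fold lower number from compound 1 to compound 2 (0.76 log units; beyond the scatter), changed only a methyl within the leaving group. The position therefore does not depend on the group with the five-membered and six-membered aromatic rings and its 2 hydrogen-bond acceptors: 3,5-difluorophenyl, with one carbon-only aromatic ring and no hydrogen-bond acceptors, gives the lower number. Nothing measured here explains this step.

The compounds shown do not separate the contribution of the two fluorines from that of the carbon-only ring. Going by these compounds, how a plain phenyl, a 3,5-dichlorophenyl or a phenyl bearing a nitrile would compare on this carbonyl carbon remains open.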